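Triazine thioethers against pro-cathepsin H: notes on compound 4

This account rests on a few compounds, and the source may have more. Where it says the series, first, only, none or still open, it means among the compounds named here.

Measured so far:
- compound 1 `COc1nc(OC)nc(Sc2ccccc2C(=O)N[C@@H](C)C(=O)OCc2ccccc2)n1` — 1.34%
- compound 2 `OCCc1ccccc1Nc1nc(Cl)nc(Cl)n1` — -11%
- compound 3 `O=c1nc(SCc2ccccc2)nc(SCc2ccccc2F)[nH]1` — "not determined" (no result reported)

In an assay for inhibition of Pro-cathepsin H (Homo sapiens), read by fluorescence, tested at 50 uM (a lower number here means less inhibition, a higher number more inhibition at the concentration tested (going by the name of the read-out)), compound 1 gives 1.34% and compound 2 gives -11%; the two values lie within the usual scatter of each other, so neither can be placed above the other, and both sit around the zero line of the read-out. Among the compounds with values here, compound 3 stands nowhere on the numbers: in this assay compound 3 gives "not determined" (no result reported), so it gives no anchor for a step.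

Compound 4 `O=C(O)CSc1nc(SCc2ccccc2)nc(=O)[nH]1` differs from compound 3 in one place: carboxy in place of 2-fluorophenyl on a saturated chain carbon bound to a sulfur. Cut one bond further out, the same change reads 2-fluorobenzyl to carboxymethyl.

Within the data shown here, with no number for compound 3, no direction for the step into compound 4 can be taken from the data; the only guide is that the two compounds measured in this assay both show essentially no inhibition, and no shift beyond the scatter is expected for compound 4 either. Compound 4 is therefore expected to give about 2% in this assay, with a range estimated from -12% to 16%.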

Compound 4, a percentage reported as inhibition, at one concentration (the size of the read-out at that concentration, not a potency): 6.89%
Compound 4: middle estimate off by 4.9 percentage points, on the low side, within the range that was stated.
By their numbers in this assay, from the lowest: compound 2; then compounds 1 and 4 (each within the scatter of the next).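

In this assay, within the data shown here, compound 3 has no number, so no step from it to compound 4 can be read. The compounds shown leave open whether replacing 2-fluorobenzyl with carboxymethyl changes inhibition at all. No supporting measurement is available to explain the value of compound 4.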